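Compound 3 gains a 3-chloro-4-fluorophenoxy group

The source may report more compounds than this note shows. Statements on the series, on what has been measured and on what is new or still open speak of the compounds shown alone.

In a physicochemical assay for lipophilicity, measured as chromatographic lipophilicity, at pH 7.4 (a higher number here means a more lipophilic compound, a lower number a more polar compound), compound 3 `COc1cc(-c2nnc3n2CCCC3(c2ccc(F)c(F)c2)C(C)(C)O)ccc1-c1cnc(C)o1` stands at 2.9 on the scale. That is within the scatter of compound 1 `COc1cc(-c2nnc3n2CCCC3c2ccc(Cl)c(Cl)c2)ccc1-c1cnc(C)o1` at 3.2 and clearly under compound 2 `COc1cc(-c2nnc3n2CCCC3(OC)c2ccc(Cl)c(Cl)c2)ccc1-c1cnc(C)o1` at 3.7 on the same scale. Compound 4 `COc1cc(-c2nnc3n2CCCC3(Oc2ccc(F)c(Cl)c2)C(C)(C)O)ccc1-c1cnc(C)o1` carries 3-chloro-4-fluorophenoxy in place of 3,4-difluorophenyl on a saturated ring carbon as its one difference. Going by the values given here, only one measured step bears on this, and only loosely: methoxy in place of hydrogen on a saturated ring carbon gave a number 0.50 log units higher from compound 1 to compound 2 (beyond the scatter) in this assay as its result. Among the compounds with values here, no measured step isolates the swap of fluorine for chlorine. With that single step as the guide, a rise of similar modest size is expected, namely a number 0.50 log units higher from compound 3 to compound 4 (beyond the scatter) by this estimate. Compound 4 is expected at 3.4 with a likely range from 3 to 3.9 on that scale.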

Compound 4, distribution coefficient: 3.2
The estimate for compound 4 lay 0.20 log units above the measured number; measured number inside the range.
By their numbers in this assay, from the lowest: compounds 3, 1 and 4 (each within the scatter of the next); then compound 2.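

In this assay the change from 3,4-difluorophenyl to 3-chloro-4-fluorophenoxy on this saturated ring carbon gives a number 0.30 log units higher from compound 3 to compound 4 (within the scatter) and so shows that exchanging the whole aromatic group here leaves the reading within the scatter. This one step changes both the linking oxygen and a halogen, so it cannot separate the two. No measurement shown here offers an explanation for this result. Still open, as far as these compounds go, is how an amine or a carboxylic acid on this ring carbon would read in this assay and whether 3,4-difluorophenoxy would match 3-chloro-4-fluorophenoxy.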